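Trading a chlorophenyl ring for a trimethoxyphenyl ring

This account rests on a few compounds, and the source may have more. Where it says the series, first, only, none or still open, it means among the compounds named here.

Measured so far in a functional assay on SN12C cells (Homo sapiens) for antiproliferative activity, with a stated time of 48 h; on this read-out higher numbers stand for weaker inhibition of growth and lower numbers for stronger inhibition of growth:
compound 1 `Cc1cc(O)c(C2=NN(c3ccc(S(N)(=O)=O)cc3)C(c3ccccc3O)C2)cc1Cl` gives 15300 nM
compound 2 `Cc1cc(O)c(C2=NN(c3ccc(S(N)(=O)=O)cc3)C(c3ccccc3Cl)C2)cc1Cl` gives 6320 nM
compound 3 `Cc1cc(O)c(C2=NN(c3ccc(S(N)(=O)=O)cc3)C(/C=C/c3ccccc3)C2)cc1Cl` gives 25600 nM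

Of these three, compound 2 has the lowest number, so it inhibits growth most strongly. The nearest is compound 1, reached by a 2.4-fold lower number from compound 1 to compound 2 (0.38 log units; beyond the scatter), and the furthest is compound 3, reached by a 4.1-fold higher number from compound 2 to compound 3 (0.61 log units; beyond the scatter). Both steps lie beyond the scatter, so the lead of compound 2 is real, though modest.

The new compound 4 `COc1ccc(C2CC(c3cc(Cl)c(C)cc3O)=NN2c2ccc(S(N)(=O)=O)cc2)c(OC)c1OC` differs from compound 2 in one place: 2,3,4-trimethoxyphenyl in place of 2-chlorophenyl on a saturated ring carbon.

Two measured steps speak to this change. Both replace or alter the 2-chlorophenyl group of compound 2. Going from the hydroxy-bearing ring to the chloro-bearing ring gave a 2.4-fold lower number from compound 1 to compound 2 (0.38 log units; beyond the scatter); swapping the chloro-bearing ring for a 2-phenylethenyl group gave a 4.1-fold higher number from compound 2 to compound 3 (0.61 log units; beyond the scatter). Every departure from the 2-chlorophenyl seen so far has raised the number. The 2,3,4-trimethoxyphenyl group is again a departure, carrying hydrogen-bond acceptors where compound 2 has none, so a modest rise in this assay is expected, a 2.2-fold higher number from compound 2 to compound 4 (0.35 log units; beyond the scatter). Compound 4 is therefore estimated at 14000 nM, with a range from 6000 nM to 35000 nM.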

Compound 4, concentration for total growth inhibition: 10300 nM
Estimate against measurement, compound 4: 1.4-fold (0.13 log units) above, and the stated range covers the measured number.
By their numbers in this assay, from the lowest: compounds 2, 4, 1 and 3 (each within the scatter of the next, the first and the last beyond it).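

At this saturated ring carbon, the 2,3,4-trimethoxyphenyl group, which is larger than 2-chlorophenyl and carries hydrogen-bond acceptors where 2-chlorophenyl has none, is accepted in this assay with a 1.6-fold higher number from compound 2 to compound 4 (0.21 log units; within the scatter), so the two groups cannot be told apart here. The earlier rule that every departure from 2-chlorophenyl raises the number therefore fails for this group, and it also cannot be separated from 2-hydroxyphenyl, with a 1.5-fold lower number from compound 1 to compound 4 (0.17 log units; within the scatter). It does separate from 2-phenylethenyl, with a 2.5-fold lower number from compound 3 to compound 4 (0.40 log units; beyond the scatter), but this does not show that any ring set directly on this carbon beats that group, since compound 1 also has such a ring and stays within the scatter of compound 3.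

The compounds shown leave open which of the three methoxy groups matter, something a ring with a single methoxy group could help to settle, and how a ring bearing an amine or a carboxylic acid would behave at this position. No measurement at hand explains the order of these groups at this position.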